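Hydroxynaphthyl hydrazone in a diaryl-ether urea series

This account rests on a few compounds, and the source may have more. Where it says the series, first, only, none or still open, it means among the compounds named here.

Compound 1 `COc1ccc(OC)c(/C=N/NC(=O)Nc2ccc(Oc3ccnc(-c4nncn4CCN(C)C)c3)c(F)c2)c1` is tested in a functional assay on HT-29 cells (Homo sapiens) for cytotoxicity, read by MTT assay, with a stated time of 72 h (on this read-out lower numbers stand for stronger inhibition and higher numbers for weaker inhibition), where compound 1 gives 2070 nM, the highest of the two numbers shown. Compound 2 `CN(C)CCn1cnnc1-c1cc(Oc2ccc(NC(=O)N/N=C/c3ccc(O)c(O)c3)cc2F)ccn1` gives 1890 nM in this assay, and the step of a 1.1-fold lower number from compound 1 to compound 2 (0.04 log units; within the scatter) shows that exchanging the aryl group on the carbon with a double bond to nitrogen left the number essentially unchanged. Compound 3 `CN(C)CCn1cnnc1-c1cc(Oc2ccc(NC(=O)N/N=C/c3c(O)ccc4ccccc34)cc2F)ccn1` carries a further exchange at the same place: 2-hydroxynaphthalen-1-yl in place of 2,5-dimethoxyphenyl on a carbon with a double bond to nitrogen. Going by the values given here, only that one step bears on it, so no change beyond the scatter is expected, a 1.2-fold lower number from compound 1 to compound 3 (0.06 log units; within the scatter). Compound 3 is therefore estimated at 1800 nM, within 700 nM to 4500 nM.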

Compound 3, half-maximal inhibitory concentration: 670 nM
Compound 3: the middle estimate sits 2.7-fold (0.43 log units) above what was measured, and the stated range ends above it.
By their numbers in this assay, from the lowest: compound 3; then compounds 2 and 1 (each within the scatter of the next).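

At the carbon with a double bond to nitrogen, the aryl group now makes a difference in this assay: 2-hydroxynaphthalen-1-yl gives a 3.1-fold lower number from compound 1 to compound 3 (0.49 log units; beyond the scatter) and a 2.8-fold lower number from compound 2 to compound 3 (0.45 log units; beyond the scatter), whereas exchanging the two single-ring aryl groups had left the number within the scatter. So this position does respond to change, at least to this exchange, which brings in a second six-membered aromatic ring. Nothing available accounts for the step. The compounds shown leave open whether the second ring or the hydroxy group carries it; a plain naphthalen-1-yl or a 2-methoxynaphthalen-1-yl group would separate the two.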